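The source may report more compounds than this note shows. Statements on the series, on what has been measured and on what is new or still open speak of the compounds shown alone.

Compound 1 `COC(=O)c1cc(-c2csc(N/N=C/c3ccc(Cl)cc3Cl)n2)ccc1OCc1ccccc1` gives 75% in a functional assay, read by spectrophotometry, with a stated time of 15 min, tested at 100 ug/mL; on this read-out higher numbers stand for a stronger effect at the one concentration tested and lower numbers for a weaker effect.
Compound 2 `Cc1ccc(-c2csc(N/N=C/c3cccs3)n2)cc1` gives 91% in this assay.
Compound 3 `COC(=O)c1cc(-c2csc(N/N=C/c3cccs3)n2)ccc1OCc1ccccc1` gives 92.4% in this assay.

Among these three numbers, compound 2 lies within the scatter of compound 3 and well above compound 1, beyond the scatter. Compound 4 `Clc1ccc(-c2csc(N/N=C/c3cccs3)n2)cc1` differs from compound 2 in a single place: chloro in place of methyl on an aromatic carbon. Among the measured compounds shown here, the only measured step, a number 17.4 percentage points higher from compound 1 to compound 3 (beyond the scatter), concerns a different part of the molecule, the group on the carbon with a double bond to nitrogen, and leaves the six-membered aromatic ring of carbon only untouched, so it gives no direct guide to exchanging methyl for chloro there. Compound 2 and compound 3 differ in what sits on that ring, yet their values lie within the scatter of each other, which hints that this ring accepts changes without a large shift. For the measured compounds named here, with no measured step on this exact change, compound 4 is expected to show the step of a number 3 percentage points lower from compound 2 to compound 4 (within the scatter), which stays inside the scatter. Compound 4 is therefore estimated at 88%, between 72% and 98%.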

Compound 4, a percentage reported as inhibition, at one concentration (the size of the read-out at that concentration, not a potency): 87.1%
The estimate for compound 4 lay 0.9 percentage points above the measured number, within the range that was stated.
By their numbers in this assay, from the lowest: compound 1; then compounds 4, 2 and 3 (each within the scatter of the next).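

Replacing methyl with chloro on an aromatic carbon, para to a large group, gives a number 3.9 percentage points lower from compound 2 to compound 4 (within the scatter) in this assay. Among the compounds shown here, this is the first direct reading of a change at this position. The earlier step concerned only the group on the carbon with a double bond to nitrogen. At the one concentration tested, this read-out does not separate methyl from chloro here in compounds that carry the thiophen-2-yl group, and no measurement shown offers an explanation for this result.

The compounds shown leave open whether an amine, a carboxylic acid or a longer chain at this position would keep the effect at this level. They also leave open whether the same exchange of methyl for chloro would read alike with the 2,4-dichlorophenyl group of compound 1 in place of thiophen-2-yl.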